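The source may report more compounds than this note shows. Statements on the series, on what has been measured and on what is new or still open speak of the compounds shown alone.

Compound 1 `Cc1cccc(N2C(=O)CSC2c2cccc(C(=O)NCCCCc3ccccc3)c2)c1` carries 3-methylphenyl on the amide-type nitrogen in a ring. In a functional assay on 143B cells (Homo sapiens) for inhibition, read by CCK-8 assay, with a stated time of 72 h, tested at 1 uM (on this read-out higher numbers stand for more inhibition at the one concentration tested (going by the name of the read-out) and lower numbers for less inhibition), compound 1 gives 71%. Compound 2 `COc1cccc(OC)c1N1C(=O)CSC1c1cccc(C(=O)NCCCCc2ccccc2)c1` differs from it at that nitrogen only, and in this assay compound 2 gives 31%; the step of a number 40 percentage points lower from compound 1 to compound 2 (beyond the scatter) is the single one measured so far in the series. On the numbers shown compound 2 stands lowest of the two, with compound 1 the nearest and higher beyond the scatter.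

Compound 3 `O=C(NCCCCc1ccccc1)c1cccc(C2SCC(=O)N2c2ccccc2F)c1` is the next member, not yet measured. Going by the values given here, its change from compound 2 is 2-fluorophenyl in place of 2,6-dimethoxyphenyl on an amide-type nitrogen in a ring, at the same place where the one measured step occurred. That step, a number 40 percentage points lower from compound 1 to compound 2 (beyond the scatter), fell when 2,6-dimethoxyphenyl entered; compound 3 now takes that group out again, so the expectation for this assay is a rise beyond the scatter, though 2-fluorophenyl has not itself been tested and the gain need not reach the level of compound 1. Compound 3 is estimated at 55% in this assay, within 30% to 80%. The expected step is a number 24 percentage points higher from compound 2 to compound 3 (beyond the scatter).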

Compound 3, a percentage reported as inhibition, at one concentration (the size of the read-out at that concentration, not a potency): 59%
Beside the measured number, compound 3's estimate is 4 percentage points below it; the range from low to high includes it.
By their numbers in this assay, from the lowest: compound 2; then compound 3; then compound 1.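

Notes on the group on the amide-type nitrogen in a ring: in this assay, the low reading with 2,6-dimethoxyphenyl does not extend to every substituted phenyl at this position, as 2-fluorophenyl gives a number 28 percentage points higher from compound 2 to compound 3 (beyond the scatter). Even so, this change does not recover everything, since the step to 2-fluorophenyl from 3-methylphenyl is a number 12 percentage points lower from compound 1 to compound 3 (beyond the scatter), so the three groups now separate beyond the scatter and the position responds to which phenyl group it carries. The change from compound 2 to compound 3 lowers the heavy-atom count and the hydrogen-bond acceptor count together, and no measurement here bears on which feature, if either, accounts for the rise.

The compounds shown leave open whether 2-methoxyphenyl, with a single methoxy group, would read with compound 2 or with compound 3, and whether 3-fluorophenyl or 2-methylphenyl would separate the identity of the substituent from its place on the phenyl ring. They also leave open how an amine such as dimethylamino on this phenyl ring would read, and, with one concentration per compound, how these percentages relate to potency.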